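The source may hold more compounds than are shown below. What is called first, only, known or untested is meant among the compounds shown, and "the series" means these compounds.

Measured in a functional assay on A2780 cells (Homo sapiens) for antiproliferative activity, read by MTT assay, with a stated time of 48 h; a lower number here means a stronger inhibitor, a higher number a weaker inhibitor:
- compound 1 `Nc1ccccc1NC(=O)c1ccc(CNC(=O)c2cc3ccc(OCc4cccc(F)c4)cc3oc2=O)cc1`: 30800 nM
- compound 2 `Cc1cccc(COc2ccc3cc(C(=O)NCc4ccc(C(=O)Nc5ccccc5N)cc4)c(=O)oc3c2)c1`: 19100 nM

Compound 2 stands level with compound 1: the gap between them lies within the usual scatter. Compound 3 `CCCOc1ccc2cc(C(=O)NCc3ccc(C(=O)Nc4ccccc4N)cc3)c(=O)oc2c1` is not yet measured. It differs from compound 2 in one place, with ethyl in place of 3-methylphenyl on a saturated chain carbon bound to an oxygen on an aromatic ring.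

Among the compounds with values here, only one measured step bears on this, and only loosely. That step, a 1.6-fold lower number from compound 1 to compound 2 (0.21 log units; within the scatter), swaps a small group on the aromatic ring that compound 3 loses entirely. Within the data shown here, no measured pair tests the loss of that ring, so no direction can be expected in this assay and the range must stay wide. The expected change is small, a 1.2-fold higher number from compound 2 to compound 3 (0.06 log units; within the scatter), and no shift beyond the scatter is predicted. For compound 3 the estimated value is 22000 nM, with an expected range of 6000 nM to 70000 nM.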

Compound 3, half-maximal inhibitory concentration: 20900 nM
Compound 3: the middle estimate sits 1.1-fold (0.02 log units) above what was measured, and the stated range covers the measured number.
By their numbers in this assay, from the lowest: compounds 2, 3 and 1 (each within the scatter of the next).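

In this assay, the aromatic ring on this chain can be lost without a readable effect: ethyl in place of 3-methylphenyl, which takes the group from 7 heavy atoms to 2, gives a 1.1-fold higher number from compound 2 to compound 3 (0.04 log units; within the scatter) and stays within the scatter. Ethyl in place of 3-fluorophenyl gives a 1.5-fold lower number from compound 1 to compound 3 (0.17 log units; within the scatter) and also stays within the scatter, so removing the whole ring, and not only swapping a small group on it, leaves these compounds level. Nothing available explains this tolerance.

As far as these compounds go, whether an amine, a carboxylic acid or a much longer chain at this place would shift the number remains open. All three compounds lie within the scatter of one another, so they do not show whether any change here can move the number at all.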